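The compounds below may be only part of what the source reports. "The series", "measured", "known", "first", "only" and "open" are said of these compounds alone.

In a functional assay on GC-2 cells (Mus musculus) for cytotoxicity, read by MTT assay, with a stated time of 72 h (on this read-out lower numbers stand for stronger inhibition and higher numbers for weaker inhibition), compound 1 `Nc1nc(Nc2ccc(S(N)(=O)=O)cc2)sc1C(=O)c1cccc([N+](=O)[O-])c1` gives 20000 nM and compound 2 `COc1cccc(C(=O)c2sc(Nc3ccc(S(N)(=O)=O)cc3)nc2N)c1` gives 11000 nM on the shared core. Going by the values given here, these are the only two numbers available and they lie within the scatter of each other, so compound 2 stands level with compound 1 and the two cannot be ranked. Compound 3 `Nc1nc(Nc2ccc(S(N)(=O)=O)cc2)sc1C(=O)c1ccccc1` carries hydrogen in place of methoxy on an aromatic carbon, going from 3-methoxyphenyl to phenyl (hydrogen in place of methoxy on an aromatic carbon). Among the compounds with values here, the one measured step that bears on this is methoxy in place of nitro, which came to a 1.8-fold lower number from compound 1 to compound 2 (0.26 log units; within the scatter) and gives only thin guidance. Within the data shown here, no measured compound shows the effect of hydrogen at this carbon. On that single step, no change beyond the scatter is expected in this assay here. The estimated step is a 1.1-fold higher number from compound 2 to compound 3 (0.04 log units; within the scatter) and it stays within that scatter. Compound 3 is therefore expected at 12000 nM with 5000 nM to 30000 nM as the estimated range.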

Compound 3, half-maximal inhibitory concentration: 6100 nM
Compound 3: the middle estimate sits 2.0-fold (0.29 log units) above what was measured, and the stated range covers the measured number.
By their numbers in this assay, from the lowest: compounds 3, 2 and 1 (each within the scatter of the next, the first and the last beyond it).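

In this assay, hydrogen in place of methoxy on this aromatic carbon gives a 1.8-fold lower number from compound 2 to compound 3 (0.26 log units; within the scatter), so these two groups cannot be ranked at this position. Hydrogen in place of nitro gives a 3.3-fold lower number from compound 1 to compound 3 (0.52 log units; beyond the scatter), the first step in this set to clear the scatter, which shows that the group on this carbon can shift the number, though only modestly, while compound 2 cannot be separated from either compound 1 or compound 3. Nothing available accounts for this difference between nitro and hydrogen.

The compounds shown leave open whether an amine or a carboxylic acid on this carbon would read like hydrogen or like nitro. They also leave open whether a chlorine or a methyl would move the number any further, and whether the other carbons of this ring respond in the same way.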